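Halogen change on the anilide of an IDO1 cyclobutane amide series

The source may report more compounds than this note shows. Statements on the series, on what has been measured and on what is new or still open speak of the compounds shown alone.

Among the measured compounds shown here, compound 1 `Cc1nccc(N2CCc3nc(C4(C(=O)Nc5ccc(F)cc5)CCC4)ccc32)n1` gives 21 nM in an assay on HeLa cells for inhibition of Indoleamine 2,3-dioxygenase 1 (Homo sapiens) (on this read-out lower numbers stand for stronger inhibition and higher numbers for weaker inhibition), the higher of the two numbers so far. Compound 2 `O=C(Nc1ccc(F)cc1)C1(c2ccc3c(n2)CCN3c2ccccn2)CCC1` gives 10.9 nM; the step of a 1.9-fold lower number from compound 1 to compound 2 (0.28 log units; within the scatter) is the only one measured, and it alters the group on the ring nitrogen, not the anilide. Compound 3 `Cc1nccc(N2CCc3nc(C4(C(=O)Nc5ccc(Cl)cc5)CCC4)ccc32)n1` differs from compound 1 as follows: chloro in place of fluoro on an aromatic carbon. For the measured compounds named here, no measured step touches this end of the molecule, so the one step on record gives no direct guide; it only shows that a change elsewhere left this assay essentially unmoved. With nothing to indicate otherwise, the expected step of a 1.2-fold lower number from compound 1 to compound 3 (0.07 log units; within the scatter) is within the scatter, in no preferred direction. Compound 3 is therefore estimated at 18 nM in this assay, with a range of 7 nM to 45 nM.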

Compound 3, half-maximal inhibitory concentration: 12.5 nM
The estimate for compound 3 lay 1.4-fold (0.16 log units) above the measured number, within the range that was stated.
By their numbers in this assay, from the lowest: compounds 2, 3 and 1 (each within the scatter of the next).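

At the carbon para to a large group on the anilide ring, the first measured change is 4-fluorophenyl to 4-chlorophenyl, and it gives a 1.7-fold lower number from compound 1 to compound 3 (0.23 log units; within the scatter) in this assay. Within the pair of compound 1 and compound 3, this position therefore carries either halogen with the read-out staying within the scatter, so fluoro is not needed here for a value in this range. No available evidence bears on what lies behind this result.

Whether the same exchange reads alike on the pyridin-2-yl analogue, compound 2, remains open, since that pair has only one member among the compounds shown. Also open, on these data alone, is how this carbon would read with something other than a halogen, such as an unsubstituted phenyl, a methoxy group, an amine or a carboxylic acid.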